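Swapping a Chlorophenyl for a Pyridylmethyl on Compound 1

This account rests on a few compounds, and the source may have more. Where it says the series, first, only, none or still open, it means among the compounds named here.

Compound 1 `Nc1ccccc1NC(=O)c1ccc(CSC(=S)N2CCN(c3ccc(Cl)cc3)CC2)cc1`: 15%
Compound 2 `Nc1ccccc1NC(=O)c1ccc(CSC(=S)N2CCc3cc([N+](=O)[O-])ccc32)cc1`: 26.8%
Compound 3 `Nc1ccccc1NC(=O)c1ccc(CSC(=S)N2CCc3ccc([N+](=O)[O-])cc32)cc1`: 30.6%

Of the compounds shown here, three sharing one core have been measured in a functional assay on MGC-803 cells (Homo sapiens) for antiproliferative activity, read by CCK-8 assay, with a stated time of 72 h, tested at 2 uM; on this read-out higher numbers stand for a stronger effect at the one concentration tested and lower numbers for a weaker effect. Compound 1 gives 15%, the lowest of the three numbers. Compound 2 gives 26.8% and compound 3 gives 30.6%, each of them beyond the scatter above compound 1. Among the compounds with values here, compounds 2 and 3, however, differ from compound 1 in more than one place, so no single structural step between measured compounds is available to lean on.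

Compound 4 `Nc1ccccc1NC(=O)c1ccc(CSC(=S)N2CCN(Cc3ccncc3)CC2)cc1` is the next compound to be measured. Its difference from compound 1 is (pyridin-4-yl)methyl in place of 4-chlorophenyl on an amine nitrogen in a ring. The group that leaves and the group that enters are of the same size in heavy atoms, and the amide and thiocarbamate parts of the core stay untouched.

With no measured step of this kind in hand, the expectation for compound 4 rests on compound 1 alone, and a step from compound 1 to compound 4 of a number 3 percentage points higher from compound 1 to compound 4 (within the scatter) is expected, which is not beyond the scatter. Compound 4 is therefore estimated to give 18% in this assay, within a range from 5% to 35%, because compound 1 gives 15% and nothing measured points clearly either way.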

Compound 4, a percentage reported as inhibition, at one concentration (the size of the read-out at that concentration, not a potency): 18.4%
Beside the measured number, compound 4's estimate is 0.4 percentage points below it; the range from low to high includes it.
By their numbers in this assay, from the lowest: compounds 1, 4, 2 and 3 (each within the scatter of the next, the first and the last beyond it).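

In this assay, within the data shown here, putting (pyridin-4-yl)methyl in place of 4-chlorophenyl on the amine nitrogen in the ring gives a number 3.4 percentage points higher from compound 1 to compound 4 (within the scatter), and this is the first step between measured compounds that differ in one place. At this position, then, a group of the same heavy-atom size that loses the chlorine, gains a ring nitrogen and carries one hydrogen-bond acceptor instead of none yields a compound that this read-out cannot tell apart from compound 1. Nothing measured here offers an explanation for this result.

This single exchange alters several features at once, so the compounds shown cannot separate the part played by the ring nitrogen from that of the chlorine or of the added methylene; a plain benzyl group on the same nitrogen would be one way to pull those apart. On these data alone, it also stays open whether any group at this position can lift the number beyond the scatter, for instance a ring bearing a carboxylic acid or an amine on a longer chain.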